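From 3,5-dibromophenyl to 3-chloro-5-cyanophenyl on the shared core

This account rests on a few compounds, and the source may have more. Where it says the series, first, only, none or still open, it means among the compounds named here.

In a functional assay on C8166 cells (Homo sapiens) for cytotoxicity, read by MTT assay (a lower number here means that less compound is tolerated, a higher number that more compound is tolerated), compound 1 `Cc1ccc(C(=O)Nc2cc(Cl)ccc2OCC(=O)Nc2ccc(S(N)(=O)=O)cc2C)cc1` gives 54200 nM, compound 2 `Cc1cc(S(N)(=O)=O)ccc1NC(=O)COc1ccc(Cl)cc1NC(=O)c1cc(Cl)cc(Cl)c1` gives 72400 nM, and compound 3 `Cc1cc(S(N)(=O)=O)ccc1NC(=O)COc1ccc(Cl)cc1NC(=O)c1cc(Br)cc(Br)c1` gives 89700 nM. Compound 3 therefore stands within the scatter of both others. Compound 4 `Cc1cc(S(N)(=O)=O)ccc1NC(=O)COc1ccc(Cl)cc1NC(=O)c1cc(Cl)cc(C#N)c1` carries 3-chloro-5-cyanophenyl in place of 3,5-dibromophenyl on a carbonyl carbon. The three measured steps at this same place bear on the change, and all stay within the scatter: a 1.3-fold higher number from compound 1 to compound 2 (0.13 log units; within the scatter), a 1.7-fold higher number from compound 1 to compound 3 (0.22 log units; within the scatter) and a 1.2-fold higher number from compound 2 to compound 3 (0.09 log units; within the scatter). No step beyond the scatter is therefore expected, and the expected change is a 1.3-fold lower number from compound 3 to compound 4 (0.11 log units; within the scatter). The estimated value for compound 4 is 70000 nM, with an expected range of 35000 nM to 130000 nM.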

Compound 4, half-maximal cytotoxic concentration: 131000 nM
Compound 4: the middle estimate sits 1.9-fold (0.27 log units) below what was measured, outside the stated range (above it).
By their numbers in this assay, from the lowest: compounds 1, 2, 3 and 4 (each within the scatter of the next, the first and the last beyond it).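

In this assay, within the data shown here, a step of a 2.4-fold higher number from compound 1 to compound 4 (0.38 log units; beyond the scatter) is the first at this position to pass the scatter, with 3-chloro-5-cyanophenyl on the carbonyl carbon. The two dihalophenyl groups do not separate from it: a 1.5-fold higher number from compound 3 to compound 4 (0.16 log units; within the scatter) and a 1.8-fold higher number from compound 2 to compound 4 (0.26 log units; within the scatter) both stay inside the scatter, the second being cyano in place of chloro on an aromatic carbon. Nothing available explains the modest step from 4-methylphenyl. Still open, on these data alone, is how an aminophenyl or a carboxyphenyl group on this carbonyl carbon would read in this assay and whether a dicyanophenyl group would extend the step.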